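The source may report more compounds than this note shows. Statements on the series, on what has been measured and on what is new or still open speak of the compounds shown alone.

Measured in a functional assay on NCI-H1650 cells (Homo sapiens) for cytotoxicity, read by MTT assay, with a stated time of 72 h; a lower number here means a stronger inhibitor, a higher number a weaker inhibitor:
- compound 1 `COc1cc(/C=C2\CN(C)C/C(=C\c3cc(OC)c(OC)c(OC)c3)C2=O)cc(OC)c1OC`: 1500 nM
- compound 2 `CCCN1C/C(=C\c2ccc(OC)c(OC)c2)C(=O)/C(=C/c2ccc(OC)c(OC)c2)C1`: 16000 nM

Of these two compounds, compound 1 stands lowest at 1500 nM, clearly below compound 2 at 16000 nM. Compound 3 `COc1cc(/C=C2\CN(C(=O)CCC(=O)O)C/C(=C\c3cc(OC)c(OC)c(OC)c3)C2=O)cc(OC)c1OC` departs from compound 1 by one change, (2-carboxyethyl)carbonyl in place of methyl on an amine nitrogen in a ring. Among the measured compounds shown here, no measured pair isolates a change at this place, so the expectation is only loosely founded. A modest move towards a higher number is expected in this assay. The estimated change is a 1.7-fold higher number from compound 1 to compound 3 (0.22 log units; within the scatter). For compound 3 the expected value is 2500 nM, with an estimated range of 600 nM to 10000 nM.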

Compound 3, half-maximal inhibitory concentration: > 60000 nM
Compound 3 was reported as a limit (the forecaster's own chance of this, stated with the estimate: 5%); middle value at least 24-fold (1.38 log units) away from the limit.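

In this assay the amine nitrogen in the ring proves sensitive to what it carries, with an at least 40-fold higher number from compound 1 to compound 3 (1.60 log units; beyond the scatter) when (2-carboxyethyl)carbonyl replaces methyl. Among the compounds shown here, this is the first step measured at this place, and it is a large one. Its size is only a lower bound, set by a limit of the assay: the limit of > 60000 nM in this assay, at which 1 of the 3 values shown sits.

The compounds shown leave open whether the loss comes from the carbonyl on the nitrogen or from the carboxylic acid at the end of the chain. A simple acetyl group, or an ester of that acid, would separate the two.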